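Benzyl sulfonamides at the ceiling of the assay

The source may hold more compounds than are shown below. What is called first, only, known or untested is meant among the compounds shown, and "the series" means these compounds.

Three compounds share one core, an ester-bearing bicyclic scaffold carrying a sulfonamide. Within the data shown here, compound 1 `CCOC(=O)c1oc2ccc(NS(=O)(=O)c3ccc(C(F)(F)F)cc3)cc2c1C` is the only one with a number: in a functional assay on HCT-116 cells (Homo sapiens) for inhibition, read by MTT assay, with a stated time of 72 h (a lower number here means a stronger inhibitor, a higher number a weaker inhibitor), compound 1 gives 24200 nM. Compound 2 `CCOC(=O)c1oc2ccc(NS(=O)(=O)c3ccc(Cl)cc3)cc2c1C` reaches only the limit of this assay and gives > 40000 nM. The step of an at least 1.6-fold higher number from compound 1 to compound 2 (0.21 log units; that floor lies within the scatter) is therefore known only as a floor, and it lies within the scatter; the numbers sit at the limit of > 40000 nM in this assay, at which 2 of the 3 values shown sit.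

Compound 3 `CCOC(=O)c1oc2ccc(N(Cc3ccccc3)S(=O)(=O)c3cccc(Br)c3)cc2c1C` differs from the first two by a benzyl on the sulfonamide nitrogen and a bromine on the sulfonyl ring, and in this assay compound 3 gives > 40000 nM, which is a limit, not a number. Compound 4 `CCOC(=O)c1oc2ccc(N(Cc3ccccc3)S(=O)(=O)c3ccc([N+](=O)[O-])cc3)cc2c1C` keeps the benzyl and changes the sulfonyl ring: 4-nitrophenyl in place of 3-bromophenyl on a sulfonyl sulfur.

Among the measured compounds shown here, no measured step covers an exchange on the sulfonyl ring within the benzyl series; the only measured exchange on that ring, an at least 1.6-fold higher number from compound 1 to compound 2 (0.21 log units; that floor lies within the scatter), moved the number at most within the scatter. The author therefore expects no step beyond the scatter in this assay from compound 3 to compound 4, as a number no higher from compound 3 to compound 4 (the limit leaves the size open). Compound 4 is estimated at 40000 nM, with a range from 15000 nM to 100000 nM, most likely again reported only as a limit.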

Compound 4, half-maximal inhibitory concentration: > 40000 nM
Compound 4: only a limit was reported; the forecaster's own chance of this, stated with the estimate: 70%; the middle value sits exactly at the limit.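

In this assay, compound 4, like compound 3, is reported only as a limit, so no step between compound 3 and compound 4 can be read: the limit of > 40000 nM in this assay, at which 3 of the 4 values shown sit.

The compounds shown leave open whether 4-nitrophenyl and 3-bromophenyl on the sulfonyl sulfur differ at all, and whether any benzyl sulfonamide on the shared core gives a number rather than a limit in this assay.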